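Replacing the 2-chlorophenyl group of compound 3

The source may report more compounds than this note shows. Statements on the series, on what has been measured and on what is new or still open speak of the compounds shown alone.

Of the compounds shown here, three sharing one core have been tested in a functional assay on HL-60 cells (Homo sapiens) for inhibition, read by MTT assay, with a stated time of 72 h; on this read-out lower numbers stand for stronger inhibition and higher numbers for weaker inhibition. Compound 1 (`Cc1nc(-c2ccccc2)c(C(=O)N2CCN(c3cccc(Cl)c3)CC2)o1`) gives 39.2 nM. Compound 3 (`Cc1nc(-c2ccccc2)c(C(=O)N2CCN(c3ccccc3Cl)CC2)o1`) gives 124 nM, the higher of the two numbers available. Compound 2 (`CC(=O)c1ccc(N2CCN(C(=O)c3oc(C)nc3-c3ccccc3)CC2)cc1`) is recorded as "not active" (no number reported) and offers no number for comparison.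

Compound 4 (`Cc1nc(-c2ccccc2)c(C(=O)N2CCN(c3ccc(C(F)(F)F)cc3)CC2)o1`) carries 4-(trifluoromethyl)phenyl in place of 2-chlorophenyl on an amine nitrogen in a ring. For the measured compounds named here, the only measured step at this place is a 3.2-fold higher number from compound 1 to compound 3 (0.50 log units; beyond the scatter), an exchange of 3-chlorophenyl for 2-chlorophenyl. It is modest in size, but it involves no trifluoromethyl group, so it is only a loose guide. Compound 2 adds a warning, since its different aryl group at this place ended as "not active" (no number reported). A modest move towards weaker inhibition is therefore expected, with wide uncertainty. The estimated change is a 2.4-fold higher number from compound 3 to compound 4 (0.38 log units; beyond the scatter). For compound 4 the expected value is 300 nM, with an estimated range from 60 nM to 1800 nM.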

Compound 4, half-maximal inhibitory concentration: > 1000 nM
Compound 4 was reported as a limit; the forecaster's own chance of this, stated with the estimate: 25%; middle value at least 3.3-fold (0.52 log units) from the limit.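

Compound 4 is recorded only as a limit, not as a number: the limit of > 1000 nM in this assay, at which 1 of the 4 values shown sits. Even so, the change of aryl group can be read as an at least 8.0-fold higher number from compound 3 to compound 4 (0.90 log units; beyond the scatter), and against the other chlorophenyl compound as an at least 25-fold higher number from compound 1 to compound 4 (1.40 log units; beyond the scatter), so this place on the ring nitrogen allows far larger losses than the exchange between the two chlorophenyl groups had shown. Together with compound 2, recorded as "not active", this leaves compound 1 and compound 3, the two chlorophenyl compounds, as the only ones shown with a number.

Going by these compounds, the true size of both new steps stays open, as does whether the loss follows from the trifluoromethyl group itself or from where it sits. On these data alone, how a plain phenyl group or a methoxy-bearing phenyl group would read at this place also remains unknown.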